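This account rests on a few compounds, and the source may have more. Where it says the series, first, only, none or still open, it means among the compounds named here.

Of the compounds shown here, two have been measured in an assay on isolated protein for inhibition of Rho-associated protein kinase 2 (Homo sapiens), read by scintillation counting, radiometric assay and 33P incorporation, with a stated time of 40 min, in the presence of a further agent that is not named here; a lower number here means a stronger inhibitor, a higher number a weaker inhibitor. Compound 1, with structure `Cc1coc2cc(OCC(=O)Nc3cccc(NC(=O)c4ccc(N(C)C)cc4)c3)ccc2c1=O`, gives 2150 nM in this assay. Compound 2, with structure `CCc1ccc(C(=O)Nc2cccc(NC(=O)COc3ccc4c(=O)ccoc4c3)c2)cc1`, gives 24 nM in this assay; it has the lowest of the two numbers, and the nearest, compound 1, stands a long way higher, well beyond the usual scatter. Within the data shown here, no pair of measured compounds differing in a single place is available, so the size of any single change is unknown.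

Compound 3, with structure `O=C(COc1ccc2c(=O)ccoc2c1)Nc1cccc(NC(=O)c2cnc(C(F)(F)F)s2)c1`, has not yet been measured in this assay. It differs from compound 2 in one place: 2-(trifluoromethyl)-1,3-thiazol-5-yl in place of 4-ethylphenyl on a carbonyl carbon. A 2-(trifluoromethyl)-1,3-thiazol-5-yl thus takes the place of the 4-ethylphenyl on the carbonyl carbon whose other neighbour is the amide-type nitrogen. Nothing measured here speaks to this change directly, so the expectation rests on compound 2 alone. Compound 3 is expected to lose some potency, with a step of a 3.3-fold higher number from compound 2 to compound 3 (0.52 log units; beyond the scatter) in this assay. Compound 3 is estimated at 80 nM, within a range from 15 nM to 400 nM.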

Compound 3, half-maximal inhibitory concentration: 10 nM
Compound 3: middle estimate off by 8.0-fold (0.90 log units), on the high side; measured number below the stated range.
By their numbers in this assay, from the lowest: compound 3; then compound 2; then compound 1.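

In this assay, the position on the carbonyl carbon whose other neighbour is the amide-type nitrogen now has its first single-place comparison: a 2.4-fold lower number from compound 2 to compound 3 (0.38 log units; beyond the scatter), a modest step that lies beyond the usual scatter. For this pair, a six-membered aromatic ring of carbon only is not needed at this position: 2-(trifluoromethyl)-1,3-thiazol-5-yl, a five-membered aromatic ring with 2 hetero atoms and 2 hydrogen-bond acceptors, gives the lower number in place of 4-ethylphenyl, which has none. Nothing measured here accounts for the step, so it stands as an observation with no established cause.

The compounds shown leave open whether the step belongs to the ring or to the trifluoromethyl group on it, a question that 2-methyl-1,3-thiazol-5-yl and 4-(trifluoromethyl)phenyl at the same position could help to separate. On these data alone, it also remains open whether 2-(trifluoromethyl)-1,3-thiazol-5-yl would give a similar step on the core of compound 1, which differs from the core shared by compound 2 and compound 3.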